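From Methoxy to Ethoxy at the Limit of the Assay

The source may hold more compounds than are shown below. What is called first, only, known or untested is meant among the compounds shown, and "the series" means these compounds.

In a functional assay on A549 cells (Homo sapiens) for inhibition, read by sulforhodamine B assay, with a stated time of 48 h (a lower number here means a stronger inhibitor of growth, a higher number a weaker inhibitor of growth), compound 1 `Cc1cc(=O)oc2cc(N=C=[Se])ccc12` gives 3600 nM. Compound 2 `COC(=[Se])Nc1ccc2c(C)cc(=O)oc2c1` gives > 100000 nM, which is a limit of the assay and not a number. The true value of compound 2 is therefore unknown, and it could lie anywhere on the weak side of that limit.

Compound 3 `CCOC(=[Se])Nc1ccc2c(C)cc(=O)oc2c1` differs from compound 2 by a single small change: methyl in place of hydrogen on a saturated chain carbon bound to an oxygen on an unsaturated carbon. In other words, methoxy becomes ethoxy, with methyl in place of hydrogen on a saturated chain carbon bound to an oxygen on an unsaturated carbon.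

For the measured compounds named here, only one measured step is available, an at least 27-fold higher number from compound 1 to compound 2 (1.44 log units; beyond the scatter). It is large, but it swaps a whole group on an aromatic carbon, so it offers only indirect guidance on this much smaller change. Compound 3 keeps the group that came with the loss of growth inhibition in compound 2, so no recovery is expected in this assay, and another limit is quite likely.

The estimated step is a number no higher from compound 2 to compound 3 (the limit leaves the size open), which is expected to stay within the scatter. For compound 3 the expected value is 100000 nM, with an estimated range from 30000 nM to 200000 nM.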

Compound 3, concentration for 50% growth inhibition: > 100000 nM
Compound 3: no number, only a limit (the forecaster's own chance of this, stated with the estimate: 65%); the middle value sits exactly at the limit.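

In this assay, going from methoxy to ethoxy brings no growth inhibition into view: compound 3 also ends at a limit of the assay rather than at a number. For the compounds shown here, the one step that can be read is an at least 27-fold higher number from compound 1 to compound 3 (1.44 log units; beyond the scatter); it is large and matches the step already seen for the methoxy compound, so the large loss relative to compound 1 holds with the ethoxy group as well, though its true size may be greater. The step for methyl in place of hydrogen cannot be read, so this change could do nothing or could weaken growth inhibition further, and all that can be said is that both compounds carrying the new group leave the assay without a measurable value: the limit of > 100000 nM in this assay, at which 2 of the 3 values shown sit.

Going by these compounds, the true values of compound 2 and compound 3 remain unknown, so any difference between methoxy and ethoxy stays hidden beyond the reach of this assay. On these data alone, whether a different group at this place, such as an amine or a much longer chain, would bring a number back within the range of the assay remains open.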